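Anilide series: adding a methoxy to the core ring

This account rests on a few compounds, and the source may have more. Where it says the series, first, only, none or still open, it means among the compounds named here.

Measured so far:
compound 1 `COc1ccc(C(=O)c2cc(OC)c(OC)c(OC)c2)cc1NC(=O)/C=C/c1ccc(C(F)(F)F)cc1`: 90 nM
compound 2 `COc1ccc(C(=O)c2cc(OC)c(OC)c(OC)c2)cc1NC(=O)/C=C/c1cccc(OC(F)(F)F)c1`: 7900 nM

In a functional assay on HeLa cells (Homo sapiens) for cytotoxicity, read by MTT assay, with a stated time of 72 h (on this read-out lower numbers stand for stronger inhibition and higher numbers for weaker inhibition), compound 1 gives 90 nM, the lowest of the two numbers in hand. Its nearest neighbour is compound 2, which in this assay gives 7900 nM. Among the measured compounds shown here, the only measured step, an 88-fold higher number from compound 1 to compound 2 (1.94 log units; beyond the scatter), concerns the aryl group on the double-bonded chain carbon and leaves the shared core untouched.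

Compound 3 `COc1cc(C(=O)c2cc(OC)c(OC)c(OC)c2)cc(NC(=O)/C=C/c2ccc(C(F)(F)F)cc2)c1OC` is still to be measured. Relative to compound 1 the change is methoxy in place of hydrogen on an aromatic carbon. For the measured compounds named here, this is a change on the core of compound 1 rather than on the chain-bound aryl group, so the single step that has been measured, an 88-fold higher number from compound 1 to compound 2 (1.94 log units; beyond the scatter), large as it is, does not bear on it. No measured pair reports what a methoxy added at this place does, and the expectation therefore rests on the change being small in size and remote from the part already shown to be sensitive.

For compound 3 the expected step from compound 1 is a 2.2-fold higher number from compound 1 to compound 3 (0.35 log units; beyond the scatter), i.e. no shift beyond the scatter or at most a modest weakening, with wide uncertainty. Compound 3 is accordingly estimated at 200 nM, with a range from 50 nM to 1500 nM.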

Compound 3, half-maximal inhibitory concentration: 3000 nM
Compound 3: the middle estimate sits 15-fold (1.18 log units) below what was measured, and the stated range ends below it.
By their numbers in this assay, from the lowest: compound 1; then compound 3; then compound 2.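

In this assay, placing a methoxy on this aromatic carbon of the core raises the number sharply (a 33-fold higher number from compound 1 to compound 3 (1.52 log units; beyond the scatter)) even though the change adds a group of just 2 heavy atoms. Sensitivity in this series is therefore not confined to the chain-bound aryl group: it extends to the shared core, at a carbon ortho to a methoxy group and meta to two large groups, and hydrogen at this carbon, as in compound 1, gives the lowest of the three numbers. Nothing available here accounts for the rise, so the step stands as an observation without an explanation.

Whether the methoxy is singular in this respect remains open, since the compounds shown do not say how fluorine, a hydroxy group, an amine or an ethoxy group would read at this same carbon. Also open, on these data alone, is whether this step would carry over to other aryl groups on the chain, such as the 3-(trifluoromethoxy)phenyl of compound 2, as only the 4-(trifluoromethyl)phenyl compounds report on this change.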